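The source may report more compounds than this note shows. Statements on the series, on what has been measured and on what is new or still open speak of the compounds shown alone.

Compound 1 `C=C(C)[C@@H]1CC=C(Cn2cc(COc3ccc(C4NC(=O)NC(C)=C4C(=O)OCC)cc3)nn2)CC1` was tested in a functional assay on HT-29 cells (Homo sapiens) for inhibition, read by sulforhodamine B assay, with a stated time of 48 h (on this read-out lower numbers stand for stronger inhibition of growth and higher numbers for weaker inhibition of growth), where compound 1 gives 77100 nM. Compound 2 `C=C(C)[C@@H]1CC=C(Cn2cc(COc3ccc(C4NC(=O)NC(C)=C4C(=O)OCC)cc3OC)nn2)CC1` differs from compound 1 by methoxy in place of hydrogen on an aromatic carbon. In this assay compound 2 reaches only a limit of the assay, > 100000 nM, not a number. The step from the first to the second is therefore an at least 1.2-fold higher number from compound 1 to compound 2 (0.11 log units; that floor lies within the scatter).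

Compound 3 `C=C(C)[C@@H]1CC=C(Cn2cc(COc3ccc(C4NC(=O)NC5=C4C(=O)CC(C)(C)C5)cc3)nn2)CC1` carries a different core; how the core of compound 3 differs from the core of compound 1 is not broken down here. In this assay compound 3 also reaches only a limit of the assay, > 100000 nM, and no number. This is the limit of > 100000 nM in this assay, at which 2 of the 3 values shown sit.

Compound 4 `C=C(C)[C@@H]1CC=C(Cn2cc(COc3ccc(C4NC(=O)NC5=C4C(=O)CC(C)(C)C5)cc3OC)nn2)CC1` has not been measured. It stands to compound 3 as compound 2 stands to compound 1, with the same change, (methoxy in place of hydrogen on an aromatic carbon). Compound 3 already sits at the limit, and the measured step of an at least 1.2-fold higher number from compound 1 to compound 2 (0.11 log units; that floor lies within the scatter) gave no gain, so the step is expected to be a step that the limit leaves unreadable from compound 3 to compound 4. Compound 4 is estimated to give 150000 nM, between 60000 nM and 400000 nM, and most likely only a limit will be reported.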

Compound 4, concentration for total growth inhibition: > 100000 nM
Compound 4 ended at the assay's limit; the forecaster's own chance of this, stated with the estimate: 85%; the middle value does not contradict the limit.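

Compound 3 and compound 4 both give only a limit and no number in this assay, so no size can be read for the change of hydrogen to methoxy between them: the limit of > 100000 nM in this assay, at which 3 of the 4 values shown sit.

Still open, going by these compounds, is whether methoxy on this aromatic ring changes growth inhibition at all when it sits on the core of compound 3.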